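The source may hold more compounds than are shown below. What is called first, only, known or untested is meant among the compounds shown, and "the series" means these compounds.

Among the compounds with values here, in a functional assay on MiaPaCa cells (Homo sapiens) for antiproliferative activity, read by MTT assay, with a stated time of 3 days (a higher number here means a weaker inhibitor, a lower number a stronger inhibitor), compound 1 (`CC(C)CN1C(=O)C=C(Cl)C1(O)c1ccccc1`) gives 15 nM and sits level with its one measured neighbour. That neighbour, compound 2 (`CC(C)CN1C(=O)C=C(Cl)C1(O)c1ccc(Cl)cc1`), gives 13 nM and the two lie within the usual scatter. Compound 3 (`O=C1C=C(Cl)C(O)(c2ccccc2)N1Cc1ccccc1`) has not been measured yet. It differs from compound 1 by phenyl in place of isopropyl on a saturated chain carbon bound to an amide-type nitrogen in a ring with phenyl in place of isopropyl on a saturated chain carbon bound to an amide-type nitrogen in a ring, which turns isobutyl into benzyl. Within the data shown here, the only measured step, a 1.2-fold lower number from compound 1 to compound 2 (0.06 log units; within the scatter) for chloro in place of hydrogen on an aromatic carbon, stays within the scatter and does not touch that chain carbon. Among the measured compounds shown here, no measured pair varies the group there, so the data offer no firm direction, and in this assay no step beyond the scatter is expected. The estimated step is small, a 1.3-fold higher number from compound 1 to compound 3 (0.12 log units; within the scatter) and no more. Compound 3 is expected at about 20 nM with a likely range from 6 nM to 70 nM as its estimate.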

Compound 3, half-maximal inhibitory concentration: 230 nM
Estimate against measurement, compound 3: 12-fold (1.06 log units) below; measured number above the stated range.
By their numbers in this assay, from the lowest: compounds 2 and 1 (each within the scatter of the next); then compound 3.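

This is the first change shown that moves the number beyond the scatter: turning isobutyl into benzyl gives, in this assay, a 15-fold higher number from compound 1 to compound 3 (1.19 log units; beyond the scatter). The group on a saturated chain carbon bound to an amide-type nitrogen in a ring therefore matters in these cells, and phenyl in place of isopropyl there weakens the compound, whereas the chloro change on the aromatic carbon gave only a 1.2-fold lower number from compound 1 to compound 2 (0.06 log units; within the scatter), within the scatter. Nothing available gives a reason for this loss.

One pair cannot say whether the aromatic ring or simply the larger group is what counts, and a cyclohexylmethyl group at this place would separate those two readings. As far as these compounds go, how a methyl group or a longer chain such as n-hexyl compares with isobutyl also stays open.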